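A few compounds are considered here, and "the series" means these few. Any claim that something is new, unique, unknown or untested is made for them only; others in the source may bear on it.

Measured compounds:
compound 1 `CSc1nc(Cl)c(C(=O)c2ccccc2)s1`: > 100000 nM
compound 2 `O=C(c1ccccc1)c1sc(N2CCCC2)nc1Cl`: 82000 nM

In a functional assay on U-373MG ATCC cells (Homo sapiens) for cytotoxicity, read by MTT assay, with a stated time of 72 h (on this read-out higher numbers stand for weaker inhibition and lower numbers for stronger inhibition), compound 1 gives a value that is a limit of the assay rather than a number (the limit of > 100000 nM in this assay, at which 1 of the 2 values shown sits). Within the data shown here, compound 2 is the only compound with a measured number here. Among the measured compounds shown here, the step of an at least 1.2-fold lower number from compound 1 to compound 2 (0.08 log units; that floor lies within the scatter) is the sole measured step, and its floor lies within the scatter, so it gives little guidance.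

Compound 3 `O=C(c1ccccc1)c1sc(N2CCCCC2)nc1Cl` differs from compound 2 by piperidin-1-yl in place of pyrrolidin-1-yl on an aromatic carbon. For the measured compounds named here, no measured step covers this change. The step of a 1.2-fold lower number from compound 2 to compound 3 (0.07 log units; within the scatter) is therefore expected to stay within the scatter, and compound 3 is estimated at 70000 nM, between 30000 nM and 150000 nM.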

Compound 3, half-maximal inhibitory concentration: 96000 nM
Estimate against measurement, compound 3: 1.4-fold (0.14 log units) below; the range from low to high includes it.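

In this assay, going from pyrrolidin-1-yl to piperidin-1-yl on this aromatic carbon gives a 1.2-fold higher number from compound 2 to compound 3 (0.07 log units; within the scatter) and so shows no difference that can be told apart from the scatter. Piperidin-1-yl in place of methylsulfanyl gives an at least 1.0-fold lower number from compound 1 to compound 3 (0.01 log units; that floor lies within the scatter) and sets no firm size for that change. Compound 1 is a limit of the assay, not a number: the limit of > 100000 nM in this assay, at which 1 of the 3 values shown sits.

From the compounds shown here alone, whether morpholine, piperazine or an open-chain amine such as diethylamino at this place would give a clearly different number stays open. So does the effect of replacing the chloro group.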